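The source may hold more compounds than are shown below. What is called first, only, known or untested is meant among the compounds shown, and "the series" means these compounds.

Measured in a functional assay on the whole organism for inhibition, with Cavia porcellus as the target (a lower number here means that less compound is needed, a higher number that more compound is needed for the effect), so far:
Compound 1 (`COc1ccccc1OCC1SCCN1C(=O)CN`) – 57 mg/kg
Compound 2 (`C=CC(=O)N1CCSC1COc1ccccc1OC`) – 74 mg/kg
Compound 3 (`CCCC(=O)CC(=O)N1CCSC1COc1ccccc1OC`) – 42 mg/kg

Compound 3 stands within the scatter of both other compounds, as a 1.4-fold lower number from compound 1 to compound 3 (0.13 log units; within the scatter) and a 1.8-fold lower number from compound 2 to compound 3 (0.25 log units; within the scatter) show. The three share one core and differ in the group on the carbonyl carbon. Compound 4 (`CCOC(=O)C(C)(C)C(=O)N1CCSC1COc1ccccc1OC`) changes that group again, with 1-(ethoxycarbonyl)-1-methylethyl in place of (propylcarbonyl)methyl, and the count of the exchange reads 1-(ethoxycarbonyl)-1-methylethyl in place of (propylcarbonyl)methyl on a carbonyl carbon in full.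

The three measured steps bear on this place. Besides the two above there is a 1.3-fold higher number from compound 1 to compound 2 (0.11 log units; within the scatter) and it too stays small. None of the three leaves the scatter. Among the measured compounds shown here, no measured compound carries the entering group, so the data offer no direction, and no step beyond the scatter is expected in this assay for this exchange. The estimated step is a 1.2-fold higher number from compound 3 to compound 4 (0.08 log units; within the scatter) and nothing larger. Compound 4 is expected at 50 mg/kg with an estimated range from 22 mg/kg to 110 mg/kg as the likely span.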

Compound 4, dose for half-maximal effect: 61 mg/kg
Compound 4: middle estimate off by 1.2-fold (0.09 log units), on the low side, and the stated range covers the measured number.
By their numbers in this assay, from the lowest: compounds 3, 1, 4 and 2 (each within the scatter of the next).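

In this assay, the group on the carbonyl carbon, whose other neighbour is the amide-type nitrogen in a ring, can now be 1-(ethoxycarbonyl)-1-methylethyl without any step leaving the scatter. This holds against all three earlier groups, with (propylcarbonyl)methyl (a 1.5-fold higher number from compound 3 to compound 4 (0.16 log units; within the scatter)), vinyl (a 1.2-fold lower number from compound 2 to compound 4 (0.08 log units; within the scatter)) and aminomethyl (a 1.1-fold higher number from compound 1 to compound 4 (0.03 log units; within the scatter)), so four different groups at this place now give numbers that cannot be told apart from their neighbours in the series. No available evidence accounts for this closeness.

The compounds shown leave open whether a carboxylic acid in place of the ethoxycarbonyl, or a phenyl ring on the carbonyl carbon, would bring a step beyond the scatter. They also leave open whether a change elsewhere on the shared core would do so.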